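A few compounds are considered here, and "the series" means these few. Any claim that something is new, unique, unknown or untested is made for them only; others in the source may bear on it.

Working notes on the benzoate series sharing one core.

Compound 1 `COC(=O)/C(=C\c1ccc(OC(=O)c2ccccc2)cc1)Sc1ccnc2cc(Cl)ccc12` gives 35700 nM in a functional assay on Jurkat E6.1 cells (Homo sapiens) for cytotoxicity, read by MTT assay, with a stated time of 24 h; a lower number here means a stronger inhibitor, a higher number a weaker inhibitor. Compound 2 `COC(=O)/C(=C\c1ccc(OC(=O)c2ccccc2OC)cc1)Sc1ccnc2cc(Cl)ccc12` gives 44700 nM in this assay and holds the highest of the three numbers, although its gaps to compound 3 and to compound 1 both fall within the scatter. Compound 3 `COC(=O)/C(=C\c1ccc(OC(=O)c2c(OC)cccc2OC)cc1)Sc1ccnc2cc(Cl)ccc12` gives 37500 nM in this assay. The step of a 1.3-fold higher number from compound 1 to compound 2 (0.10 log units; within the scatter) and the step of a 1.2-fold lower number from compound 2 to compound 3 (0.08 log units; within the scatter) each add methoxy in place of hydrogen on an aromatic carbon of the benzoate ring, and neither moved the number beyond the scatter. The larger change a 1.1-fold higher number from compound 1 to compound 3 (0.02 log units; within the scatter) likewise stayed within it.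

Compound 4 `COC(=O)/C(=C\c1ccc(OC(=O)c2ccc(OC)cc2OC)cc1)Sc1ccnc2cc(Cl)ccc12` differs from compound 2 by methoxy in place of hydrogen on an aromatic carbon. The two measured methoxy additions bear directly on this change, and both were within the scatter, so nothing in the three compounds points to a shift beyond it for compound 4. For compound 4 the expected step is a 1.1-fold lower number from compound 2 to compound 4 (0.04 log units; within the scatter), a change not beyond the scatter. The estimate for compound 4 in this assay is 41000 nM, with a range from 24000 nM to 70000 nM.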

Compound 4, half-maximal inhibitory concentration: 10200 nM
Beside the measured number, compound 4's estimate is 4.0-fold (0.60 log units) above it; measured number below the stated range.
By their numbers in this assay, from the lowest: compound 4; then compounds 1, 3 and 2 (each within the scatter of the next).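

In this assay, methoxy in place of hydrogen on an aromatic carbon now moves the number beyond the scatter, with a 4.4-fold lower number from compound 2 to compound 4 (0.64 log units; beyond the scatter) for the addition para to a large group and meta to a methoxy group, so compound 3, whose added methoxy stayed within the scatter, goes against any reading that every such addition behaves alike. The count of methoxy groups alone does not account for the result, since 2,4-dimethoxyphenyl in place of 2,6-dimethoxyphenyl on a carbonyl carbon gives a 3.7-fold lower number from compound 3 to compound 4 (0.57 log units; beyond the scatter), and the same group put where phenyl stood gives a 3.5-fold lower number from compound 1 to compound 4 (0.54 log units; beyond the scatter), so within these four compounds the step follows where the second methoxy sits. No measurement at hand speaks to what lies behind this step.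

The compounds shown leave open whether a methoxy para to a large group would give a step of this size without the methoxy it sits meta to. They also leave open what another group at that place, such as an amine, a carboxylic acid or a longer chain like butoxy, would do to the number.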